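The source may hold more compounds than are shown below. What is called first, only, known or untested is meant among the compounds shown, and "the series" means these compounds.

Working notes on a shared core, with the aryl group on the amine nitrogen varied, tested in a functional assay on A549 cells (Homo sapiens) for cytotoxicity, read by MTT assay, with a stated time of 48 h; a lower number here means a stronger inhibitor, a higher number a weaker inhibitor. Compound 1 `COc1ccc(-c2nc(C(=O)/C=C\Nc3ccc(Cl)cc3)c3ccccn23)cc1` carries the 4-chlorophenyl on the amine nitrogen; in this assay compound 1 gives "not determined" (no result reported). Compound 2 `COc1ccc(N/C=C\C(=O)c2nc(-c3ccc(F)cc3)n3ccccc23)cc1OC` carries the 3,4-dimethoxyphenyl on the amine nitrogen. In this assay compound 2 reaches > 30000 nM, which is a limit of the measurement and not a number. Where compound 2 stands: the limit of > 30000 nM in this assay, at which 1 of the 2 values shown sits. Compound 3 `O=C(/C=C\Nc1ccc(Cl)cc1)c1nc(-c2ccc(F)cc2)n2ccccc12` is the next entry to be measured. The change is 4-chlorophenyl in place of 3,4-dimethoxyphenyl on an amine nitrogen. Among the measured compounds shown here, no step between two measured compounds exists in this set, so nothing measured calibrates this exchange. The step from a number no higher from compound 2 to compound 3 (the limit leaves the size open) is expected to stay within the scatter, with no direction assigned. For compound 3 the estimate is 30000 nM, with a range from 10000 nM to 100000 nM, and a report of only a limit is expected to remain the likely outcome.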

Compound 3, half-maximal inhibitory concentration: 5090 nM
The estimate for compound 3 lay 5.9-fold (0.77 log units) above the measured number; the measured number lies below the stated range.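

In this assay, the exchange on the amine nitrogen gives an at least 5.8-fold lower number from compound 2 to compound 3 (0.77 log units; beyond the scatter), the first sign that the aryl group at this position affects the read-out and that 4-chlorophenyl gives a single number where 3,4-dimethoxyphenyl does not. Compound 2 stands at > 30000 nM, which is a limit of the assay and not a number. The step therefore fixes a direction and a minimum size, while its full size stays unknown: the limit of > 30000 nM in this assay, at which 1 of the 3 values shown sits.

The exchange changes the ring's substituents as a whole, so the shown compounds cannot separate the gain of the chlorine from the loss of the two methoxy groups. Whether a plain phenyl or a 4-methoxyphenyl on the amine nitrogen would stand with compound 3 or with compound 2 remains open, as does any cause of the step.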